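This account rests on a few compounds, and the source may have more. Where it says the series, first, only, none or still open, it means among the compounds named here.

Compound 1 `CC(C)C[C@@H](N)CN(C(=O)[C@@H]1C[C@H]1c1ccccc1)c1ccc(-c2ccccc2)cc1`: 1.8 nM in a functional assay for agonist activity at G protein-coupled receptor 88 (Homo sapiens), read by HTRF and cAMP accumulation; a higher number here means that more compound is needed for the effect, a lower number that less compound is needed
Compound 2 `CO[C@H](C)[C@H](N)CN(C(=O)[C@@H]1C[C@H]1c1ccccc1)c1ccc(-c2ccccc2)cc1`: 0.68 nM in this assay
Compound 3 `CC[C@H](C)[C@H](N)CN(C(=O)[C@@H]1C[C@H]1c1cccc(OC)c1)c1ccc(-c2ccccc2)cc1`: 3000 nM in this assay

Compound 3 stands at the highest number of the three, far from compound 1 and further still from compound 2; it differs from each of them in more than one place, so only the values themselves speak. Among the measured compounds shown here, the single measured one-place step, a 2.6-fold lower number from compound 1 to compound 2 (0.42 log units; beyond the scatter), concerns the saturated chain carbon bound to the amide-type nitrogen and says nothing about the aromatic ring. Compound 4 `CC[C@H](C)[C@H](N)CN(C(=O)[C@@H]1C[C@H]1c1cccc(C#N)c1)c1ccc(-c2ccccc2)cc1` differs from compound 3 by cyano in place of methoxy on an aromatic carbon. For the measured compounds named here, no measured step bears on this change, so the expectation rests on compound 3 alone: a step of no change at the digits printed from compound 3 to compound 4 (within the scatter) in this assay, that is, none beyond the scatter, with wide uncertainty. Compound 4 is therefore estimated at 3000 nM, within 600 nM to 15000 nM.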

Compound 4, half-maximal effective concentration: 1600 nM
Estimate against measurement, compound 4: 1.9-fold (0.27 log units) above; the range from low to high includes it.
By their numbers in this assay, from the lowest: compound 2; then compound 1; then compounds 4 and 3 (each within the scatter of the next).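

Cyano in place of methoxy on this aromatic carbon gives a 1.9-fold lower number from compound 3 to compound 4 (0.27 log units; within the scatter) in this assay, the first step shown at this position, and it stays inside the scatter. At this place, then, the two groups cannot be told apart, and compound 4 remains at a high number as compound 3 does. Nothing available explains this result.

The compounds shown leave open whether a group at this aromatic carbon accounts for the distance from compounds 1 and 2, since those differ from compounds 3 and 4 in more than one place. As far as these compounds go, how fluoro, hydroxyl or an amine would read here also remains open.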